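The source may hold more compounds than are shown below. What is called first, only, known or untested is meant among the compounds shown, and "the series" means these compounds.

Measured so far in a functional assay on HeLa cells (Homo sapiens) for inhibition, read by CCK-8 assay, with a stated time of 48 h; on this read-out higher numbers stand for weaker inhibition and lower numbers for stronger inhibition:
- compound 1 `COc1ccc(Oc2ccccc2-c2ccsc2S(=O)(=O)N2CCN(C(=O)Nc3cccc([N+](=O)[O-])c3)CC2)cc1OC` gives > 50000 nM (a limit)
- compound 2 `COc1ccc(Oc2ccccc2-c2ccsc2S(=O)(=O)N2CCN(C(=S)Nc3ccc(Cl)cc3)CC2)cc1OC` gives > 50000 nM (a limit)

Compound 2 stands only at the limit > 50000 nM and has no numerical value. The same holds for the other measured compound, and the two together make up (the limit of > 50000 nM in this assay, at which 2 of the 2 values shown sit).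

The next compound is compound 3 `COc1ccc(Oc2ccccc2-c2ccsc2S(=O)(=O)N2CCN(C(=O)Nc3ccc(F)cc3)CC2)cc1OC`, not yet measured. The change is a group of 10 heavy atoms (7 carbon, 1 nitrogen, 1 oxygen, 1 fluorine; one six-membered aromatic ring of carbon only) in place of a group of 10 heavy atoms (7 carbon, 1 nitrogen, 1 sulfur, 1 chlorine; one six-membered aromatic ring of carbon only), on an amine nitrogen in a ring.

Going by the values given here, the one measured step bearing on this is a step that the two limits leave unreadable from compound 1 to compound 2, so it gives no size and no direction. Among the compounds with values here, with only that step as a guide, compound 3 is expected to stay near the same limit in this assay, although a measurable value remains possible.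

The expected step is a number no higher from compound 2 to compound 3 (the limit leaves the size open).

Compound 3 is estimated at 50000 nM, with an expected range of 12000 nM to 100000 nM.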

Compound 3, half-maximal inhibitory concentration: > 20000 nM
Compound 3: a limit, no number; the forecaster's own chance of this, stated with the estimate: 65%; the middle value does not contradict the limit.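

In this assay compound 3 gives > 20000 nM, which is a limit and not a number. Going by these compounds alone, with compound 1 and compound 2 also at limits, no step among the three can be read. The compounds shown leave open whether any of these groups on the ring nitrogen gives a measurable value in this assay.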